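Working notes: step from compound 2 to compound 3

The source may report more compounds than this note shows. Statements on the series, on what has been measured and on what is new or still open speak of the compounds shown alone.

The series begins with compound 1 `CCOC(=O)/C=C/[C@H]1C[C@@H](O)[C@@H](O)C1` and compound 2 `O=C(/C=C/[C@H]1C[C@@H](O)[C@@H](O)C1)Nc1ccc(F)cc1`, which share the core. In an ADME assay on S2 cells (Drosophila melanogaster) for cytotoxicity, read by MTT assay (on this read-out higher numbers stand for an effect only at larger amounts of compound and lower numbers for an effect already at smaller amounts), compound 1 gives only a limit, > 350000 nM. In this assay compound 2 likewise gives only a limit, > 180000 nM. Compound 2 thus stands at a limit, and the other value shown is also a limit, so the numbers allow no ordering of compound 2 against compound 1. Among the compounds with values here, no step between measured compounds is available.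

Compound 3 `CN(C)c1ccc(NC(=O)/C=C/[C@H]2C[C@@H](O)[C@@H](O)C2)cc1` differs from compound 2 in one place: dimethylamino in place of fluoro on an aromatic carbon. With both measured values sitting at limits (the limit of > 180000 nM in this assay, at which 1 of the 2 values shown sits, (the limit of > 350000 nM in this assay, at which 1 of the 2 values shown sits)), no direction for this change can be read, and in this assay no step beyond the scatter is expected. The estimate for compound 3 is 200000 nM, with a range from 100000 nM to 400000 nM. The step this estimate implies, a step that the limit leaves unreadable from compound 2 to compound 3, is expected to stay within the scatter, and a limit rather than a number is the likelier outcome.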

Compound 3, half-maximal effective concentration: > 170000 nM
Compound 3: a limit, no number; the forecaster's own chance of this, stated with the estimate: 75%; the middle value is on the limit's open side.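

In this assay, within the data shown here, compound 2 and compound 3 both give limits rather than numbers, so no step between them can be read. The compounds shown leave open whether dimethylamino in place of fluoro on an aromatic carbon changes the read-out at all.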